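Pyridin-2-yl to 4-Methyl-1,3-thiazol-2-yl on an Amide Nitrogen

The source may report more compounds than this note shows. Statements on the series, on what has been measured and on what is new or still open speak of the compounds shown alone.

Compound 1: `CC(C)C(c1ccc(Cl)cc1)S(=O)(=O)Nc1nccs1` gives < 30% in a functional assay on CHO cells for agonist activity at Free fatty acid receptor 2 (Homo sapiens), read by cAMP accumulation (a lower number here means a smaller maximal response, a higher number a larger maximal response), which is a limit of the assay rather than a number.
Compound 2: `CC(C)[C@H](C(=O)Nc1ccccn1)c1ccc(Cl)cc1` gives 92% in this assay.

Going by the values given here, compound 2 holds the only actual number among the two results. Compound 1 sits at the limit of this assay (the limit of < 30% in this assay, at which 1 of the 2 values shown sits). Compound 3, `Cc1csc(NC(=O)[C@H](c2ccc(Cl)cc2)C(C)C)n1`, has not yet been measured in this assay. It differs from compound 2 in one place: 4-methyl-1,3-thiazol-2-yl in place of pyridin-2-yl on an amide-type nitrogen. Among the compounds with values here, no measured pair shows what such a swap on an amide-type nitrogen does here, so the direction of the step is open. Compound 3 is expected to keep much of the response, with a step of a number 17 percentage points lower from compound 2 to compound 3 (beyond the scatter) that may reach beyond the usual scatter. Compound 3 is therefore estimated at 75%, within a range from 35% to 100%.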

Compound 3, largest response reached (reported as efficacy), in percent of the reference or control that the assay uses: 87%
Compound 3: the middle estimate sits 12 percentage points below what was measured; measured number inside the range.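

In this assay the swap on the amide-type nitrogen gives a number 5 percentage points lower from compound 2 to compound 3 (within the scatter) and so the two compounds cannot be told apart. This first measured pair at this position shows that a large maximal response does not depend on pyridin-2-yl, since a five-membered aromatic ring with 2 hetero atoms, as 4-methyl-1,3-thiazol-2-yl, serves as well as a six-membered aromatic ring with 1 hetero atom. Nothing shown here explains why the response holds across this swap.

The compounds shown leave open whether an aromatic ring on this nitrogen is needed at all, as a plain phenyl ring or an open alkyl chain such as a butyl group there would tell. They also leave open whether the methyl on the thiazole contributes, which the unsubstituted thiazol-2-yl amide would settle.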